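Ring-opened amines on the quinoline core: compound 4

The compounds below may be only part of what the source reports. "The series", "measured", "known", "first", "only" and "open" are said of these compounds alone.

Compound 1 `CC1CCN(c2ccc3cc(NC(=O)CCc4ccc(C(F)(F)F)cc4)ccc3n2)C1` is the reference point of this set. In an assay on isolated protein for displacement of a labelled ligand from melanin-concentrating hormone receptor 1 (Homo sapiens) (on this read-out lower numbers stand for stronger inhibition and higher numbers for weaker inhibition), compound 1 gives 2 nM, the lowest of the two single numbers in hand. Compound 2 `CN(C)c1ccc2cc(NC(=O)CCc3ccc(C(F)(F)F)cc3)ccc2n1` gives 13 nM in this assay; compound 3 `O=C(CCc1ccc(C(F)(F)F)cc1)Nc1ccc2nc(N3CCCC3)ccc2c1` was run twice and gives 3 nM; 3 nM (2 entries) each time, so its figures sit close to those of compound 1 and no order between those two is claimed.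

Compound 4 `CCN(CC)c1ccc2cc(NC(=O)CCc3ccc(C(F)(F)F)cc3)ccc2n1` has not yet been measured. It differs from compound 1 in one place: diethylamino in place of 3-methylpyrrolidin-1-yl on an aromatic carbon.

Going by the values given here, the one measured step that speaks to this change is a 6.5-fold higher number from compound 1 to compound 2 (0.81 log units; beyond the scatter), where the same ring was also replaced by an acyclic amine. Going from dimethylamino to diethylamino is not covered by any measured pair, so the guidance is the direction and size of that single step. On that basis compound 4 is expected to lose some ground against compound 1 in this assay, with a step of about a 3.5-fold higher number from compound 1 to compound 4 (0.54 log units; beyond the scatter) expected, in the same direction as the step to compound 2 but not necessarily of the same size. The value for compound 4 is therefore estimated at 7 nM, with a plausible range from 2.5 nM to 20 nM.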

Compound 4, half-maximal inhibitory concentration: 88 nM
For compound 4 the middle estimate is 13-fold (1.10 log units) below the measured one; the measured number lies above the stated range.
By their numbers in this assay, from the lowest: compound 1; then compound 2; then compound 4.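

In this assay, the place next to the ring nitrogen proves more sensitive to an acyclic amine than compound 2 alone suggested: diethylamino in place of 3-methylpyrrolidin-1-yl gives a 44-fold higher number from compound 1 to compound 4 (1.64 log units; beyond the scatter). The acyclic amines also separate from one another, with diethylamino in place of dimethylamino giving a 6.8-fold higher number from compound 2 to compound 4 (0.83 log units; beyond the scatter), so the outcome at this place is not set by the absence of a ring alone but also varies with the groups on the amine nitrogen. No supporting data are available to explain either step.

Still open, as far as these compounds go, is whether the number keeps rising with a longer chain on the amine nitrogen, as in dipropylamino, or whether a six-membered ring such as piperidin-1-yl or morpholin-4-yl stays close to compound 1 in this assay. Also open, from the compounds shown here alone, is where a mixed amine such as ethylmethylamino falls relative to compound 2 and compound 4, which would show whether a single ethyl group is enough to produce the rise.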